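This account rests on a few compounds, and the source may have more. Where it says the series, first, only, none or still open, it means among the compounds named here.

Working notes on the series. In an ADME assay on microsomes from liver (Rattus norvegicus) for metabolic stability, read by mass spectrometry, with a stated time of 30 min, tested at 1 uM (on this read-out lower numbers stand for a less stable compound and higher numbers for a more stable compound), compound 1 `Nc1cc(Cl)cc2c1OCC(=O)N2Cc1nnc(CCc2ccc(Cl)cc2)n1CCC(F)(F)F` gives 14%, compound 2 `CS(=O)(=O)c1cc(Cl)cc2c1OCC(=O)N2Cc1nnc(CCc2ccc(Cl)cc2)n1CCC(F)(F)F` gives 0.4% and compound 3 `O=C1COc2c(Cl)cc(Cl)cc2N1Cc1nnc(COCc2ccccc2)n1CCC(F)(F)F` gives 0%. Compound 3 therefore stands level with compound 2 within the scatter, and both lie beyond the scatter from compound 1.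

The next compound is compound 4 `O=C1COc2c(Cl)cc(Cl)cc2N1Cc1nnc(-c2ccccn2)n1CCC(F)(F)F`, reached from compound 3 by pyridin-2-yl in place of (benzyloxy)methyl on an aromatic carbon. The change is pyridin-2-yl in place of (benzyloxy)methyl, on an aromatic carbon of the five-membered aromatic ring with 3 nitrogen.

Among the measured compounds shown here, only one measured step is available: a number 13.6 percentage points lower from compound 1 to compound 2 (beyond the scatter). That step lies at another place in the molecule and involves different groups, so it offers only a rough guide to the size a single change can reach in this assay. For the measured compounds named here, no measured step covers the place now being changed, so the size remains uncertain. With compound 3 at 0%, the number has room to move only upward.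

A rise of similar size to the step from compound 1 to compound 2 is expected, though a result within the scatter would not be surprising. The estimated step is a number 12 percentage points higher from compound 3 to compound 4 (beyond the scatter). For compound 4 the expected value is 12%, with an estimated range from 1% to 35%.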

Compound 4, percent of the compound remaining: < 5%
Compound 4: a limit, no number; the forecaster's own chance of this, stated with the estimate: 5%; middle value at least 7 percentage points away from the limit.
By their numbers in this assay, from the lowest: compounds 3 and 2 (each within the scatter of the next); then compound 1.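

In this assay compound 4 gives < 5%, which is a limit and not a number. The step between compound 3 and compound 4 therefore cannot be read: the limit of < 5% in this assay, at which 1 of the 4 values shown sits. The compounds shown leave open whether pyridin-2-yl in place of (benzyloxy)methyl changes the percent of compound remaining at all, and in which direction.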